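The source may hold more compounds than are shown below. What is called first, only, known or untested is meant among the compounds shown, and "the series" means these compounds.

Working notes on the series. Compound 1 `C=CC1=C(C(=O)NCCCCC)C(c2ccc(OC)cc2)OC1`, compound 2 `C=CC1=C(C(=O)Nc2ccccc2)C(c2ccc(Cl)c(Cl)c2)OC1` and compound 3 `C=CC1=C(C(=O)Nc2ccccc2OC)C(c2ccc(F)cc2)OC1` share one core and have each been tested in a functional assay on A549 cells (Homo sapiens) for cytotoxicity, read by MTT assay, with a stated time of 24 h; on this read-out higher numbers stand for weaker inhibition and lower numbers for stronger inhibition. In this assay, going by the values given here, compound 1 gives 36500 nM, the only number among the three results. For compound 2 the assay reports a limit only, > 100000 nM. For compound 3 the result is likewise a limit, > 100000 nM. Among the compounds with values here, both of those sit at the limit of > 100000 nM in this assay, at which 2 of the 3 values shown sit, so compound 1 stands as the sole compound with a measurable value, and no order among the three can be stated.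

Compound 4 `C=CC1=C(C(=O)NC(C)(C)C)C(c2ccc(OC)cc2)OC1` is not yet measured. It differs from compound 1 in one place: tert-butyl in place of pentyl on an amide-type nitrogen. Within the data shown here, no measured pair carries this change, so the expectation rests on compound 1 alone and on the weak level it shows. In this assay the expected step is a 1.4-fold higher number from compound 1 to compound 4 (0.14 log units; within the scatter), a step not beyond the scatter, in either direction. Compound 4 is estimated at 50000 nM, with a range from 20000 nM to 100000 nM.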

Compound 4, half-maximal inhibitory concentration: > 100000 nM
Compound 4 ended at the assay's limit; the forecaster's own chance of this, stated with the estimate: 35%; middle value at least 2.0-fold (0.30 log units) from the limit.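

In this assay, tert-butyl in place of pentyl on the amide-type nitrogen gives the series its first readable step: an at least 2.7-fold higher number from compound 1 to compound 4 (0.43 log units; beyond the scatter). The size of this step is only a lower bound, as the result for compound 4 is a limit and not a number. This position therefore responds to the change, and within this single pair the measurable activity goes with the pentyl chain, with the rest of compound 1 held constant, and the series now leans heavily on that one number: the limit of > 100000 nM in this assay, at which 3 of the 4 values shown sit.

Going by these compounds, how far compound 4 lies past the limit stays open, as does whether the chain length or the branching carries the step. A hexyl chain, or a chain ending in an amine, on this nitrogen would show whether the number of compound 1 can move in the stronger direction.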